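Swapping the Furan Attachment in a Small Series

The compounds below may be only part of what the source reports. "The series", "measured", "known", "first", "only" and "open" are said of these compounds alone.

Three compounds sharing one core have been examined in an assay on membranes from CHO cells for displacement of a labelled ligand from adenosine receptor A1 (Homo sapiens), read by scintillation counting, with a stated time of 60 min, tested at 1 uM; on this read-out higher numbers stand for more inhibition at the one concentration tested (going by the name of the read-out) and lower numbers for less inhibition. Compound 1 `COC(=O)C1=C(C)NC(=O)NC1c1ccoc1` gives 8%. Going by the values given here, compound 2 `CCCC(=O)C1=C(C)NC(=O)NC1c1ccoc1` gives 1% in this assay, and the only measured step between compounds differing in one place is a number 7 percentage points lower from compound 1 to compound 2 (within the scatter), a change at the carbonyl carbon. Compound 3 `CCNC(=O)C1=C(C)NC(=O)NC1c1ccco1` gives 2% in this assay; of the three numbers it is the second highest, with compound 2 nearest and compound 1 furthest, both within the scatter of it.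

Compound 4 `CCNC(=O)C1=C(C)NC(=O)NC1c1ccoc1` has not yet been measured. It differs from compound 3 in one place: furan-3-yl in place of furan-2-yl on a saturated ring carbon. Among the compounds with values here, no measured step concerns this change directly; the step from compound 1 to compound 2 involves a different position. What the data do show is that compound 1 and compound 2, both carrying the furan-3-yl group, give numbers within the scatter of compound 3 with its furan-2-yl group, and all three sit low in this assay. A step no larger than the scatter is therefore expected, as a number 1 percentage points higher from compound 3 to compound 4 (within the scatter). Compound 4 is estimated at 3%, with a range from -6% to 12%.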

Compound 4, a percentage reported as inhibition, at one concentration (the size of the read-out at that concentration, not a potency): 1%
Beside the measured number, compound 4's estimate is 2 percentage points above it, within the range that was stated.
By their numbers in this assay, from the lowest: compounds 2, 4, 3 and 1 (each within the scatter of the next).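

In this assay, going by these compounds alone, furan-3-yl in place of furan-2-yl on a saturated ring carbon gives the first direct reading of this change, with the ethylcarbamoyl group held the same on both sides: a number 1 percentage points lower from compound 3 to compound 4 (within the scatter), so the point of attachment of the furan does not separate these two compounds on this read-out. With furan-3-yl held the same, the group on the carbonyl carbon can now be read across three compounds: ethylamino in place of propyl gives no change at the digits printed from compound 2 to compound 4 (within the scatter), ethylamino in place of methoxy gives a number 7 percentage points lower from compound 1 to compound 4 (within the scatter), and neither of these steps, like a number 7 percentage points lower from compound 1 to compound 2 (within the scatter), lies beyond the scatter. No supporting measurement bears on this result, and the numbers alone offer no explanation for it.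

From the compounds shown here alone, each number comes from a single concentration, so it remains open whether the two furan attachments would differ at any other concentration. Going by these compounds, it also remains open whether a phenyl group on the saturated ring carbon, or an amine or a longer chain on the carbonyl carbon, would move the number beyond the scatter.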